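Phenyl for cycloheptyl on the ether oxygen

A few compounds are considered here, and "the series" means these few. Any claim that something is new, unique, unknown or untested is made for them only; others in the source may bear on it.

Three chloroacetyl ureas carrying an ether on the aromatic ring have been run in a functional assay on M21 cells (Homo sapiens) for inhibition, read by sulforhodamine B assay, with a stated time of 48 h; on this read-out higher numbers stand for weaker inhibition of growth and lower numbers for stronger inhibition of growth. Compound 1 `O=C(CCl)NC(=O)Nc1ccc(OC2CCCCCC2)cc1` gives 5000 nM in this assay. Compound 3 `O=C(CCl)NC(=O)Nc1ccc(Oc2ccccc2)cc1` differs from it by phenyl in place of cycloheptyl on an oxygen on an aromatic ring and gives 4200 nM in this assay; the step is a 1.2-fold lower number from compound 1 to compound 3 (0.08 log units; within the scatter). Compound 2 `O=C(CCl)NC(=O)Nc1cccc(OC2CCCCCC2)c1` has the same atoms as compound 1 joined differently; the difference between the two cores is not broken down here. In this assay compound 2 gives 4200 nM, level with compound 3 and within the scatter of compound 1.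

Compound 4 `O=C(CCl)NC(=O)Nc1cccc(Oc2ccccc2)c1` has not been measured. It relates to compound 2 as compound 3 relates to compound 1: phenyl in place of cycloheptyl on an oxygen on an aromatic ring, the same change at the same place, both on an oxygen on an aromatic ring whose other neighbours are aromatic carbon. Among the compounds with values here, only one prior instance of this change exists, and it lay within the scatter. For compound 4 the expected step is therefore a 1.2-fold lower number from compound 2 to compound 4 (0.08 log units; within the scatter), resting on a 1.2-fold lower number from compound 1 to compound 3 (0.08 log units; within the scatter). Compound 4 is estimated at 3500 nM in this assay, with a likely range from 1500 nM to 8000 nM.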

Compound 4, concentration for 50% growth inhibition: 5300 nM
Compound 4: the middle estimate sits 1.5-fold (0.18 log units) below what was measured; the range from low to high includes it.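

In this assay, phenyl in place of cycloheptyl on the ether oxygen gives a 1.3-fold higher number from compound 2 to compound 4 (0.10 log units; within the scatter), a step within the scatter, as on the core of compound 1. The two instances cannot be told apart on this read-out: the same change on two cores in this assay, a 1.2-fold lower number (0.08 log units; within the scatter) from compound 1 to compound 3 and a 1.3-fold higher number (0.10 log units; within the scatter) from compound 2 to compound 4, 1.5-fold (0.18 log units) apart, within the scatter of two such steps. This shows that the change carried across these two cores without a step distinguishable from scatter, but it gives no direction for the change, does not show that the two groups are interchangeable elsewhere in the series, and does not show how a step beyond the scatter would carry from one core to another.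

The compounds shown carry only cycloheptyl or phenyl on the ether oxygen, so it remains open whether any other group there would move growth inhibition beyond the scatter. A longer straight chain in that place, or an amine or a carboxylic acid on the phenyl, would put this to the test on both cores.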